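The source may hold more compounds than are shown below. What is called first, only, known or untested is meant among the compounds shown, and "the series" means these compounds.

In an ADME assay on L02 cells (Homo sapiens) for cytotoxicity, read by MTT assay, with a stated time of 24 h (a higher number here means a weaker inhibitor, a lower number a stronger inhibitor), compound 3 `O=C1/C(=C/c2ccncc2)CNC/C1=C\c1ccccc1F` gives 14700 nM and so lies within the scatter of compound 1 `COc1cc(/C=C2\CN(C)C/C(=C\c3ccncc3)C2=O)cc(OC)c1` at 13400 nM and of compound 2 `O=C1/C(=C/c2cccnc2)CNC/C1=C\c1ccccc1F` at 15900 nM as well. Compound 4 `N#Cc1ccc(S(=O)(=O)N2C/C(=C\c3ccncc3)C(=O)/C(=C/c3ccccc3F)C2)cc1` differs from compound 3 by one change, (4-cyanophenyl)sulfonyl in place of hydrogen on an amine nitrogen in a ring. For the measured compounds named here, the one measured step (a 1.1-fold lower number from compound 2 to compound 3 (0.03 log units; within the scatter)) puts pyridin-4-yl in place of pyridin-3-yl, lies within the scatter and leaves this nitrogen untouched, so no measured step speaks directly to the new group. On that thin basis, the step expected in this assay is none beyond the scatter (a 1.3-fold lower number from compound 3 to compound 4 (0.13 log units; within the scatter)), though with wide uncertainty. The estimated value for compound 4 is 11000 nM with a broad expected range (3000 nM to 30000 nM).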

Compound 4, half-maximal inhibitory concentration: > 20000 nM
Compound 4 gave a limit, no number; the forecaster's own chance of this, stated with the estimate: 8%; middle value at least 1.8-fold (0.25 log units) away from the limit.
By their numbers in this assay, from the lowest: compounds 1, 3 and 2 (each within the scatter of the next). At a limit, above all of these: compound 4.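

In this assay, for the compounds shown here, the first change on the amine nitrogen in the ring gives an at least 1.3-fold higher number from compound 3 to compound 4 (0.13 log units; that floor lies within the scatter). Compound 4 stands at a limit, > 20000 nM, and this is not a number. So (4-cyanophenyl)sulfonyl on this nitrogen brings no lower reading, yet the floor of the step stays within the scatter and the true size of the change is unknown. On these data alone, how far compound 4 lies past this limit stays open, as does whether the nitrile matters. A plain phenylsulfonyl or an acetyl group on this nitrogen would help separate these.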